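A few compounds are considered here, and "the series" means these few. Any claim that something is new, unique, unknown or untested is made for them only; others in the source may bear on it.

In a functional assay on DU-145 cells (Homo sapiens) for inhibition, read by trypan blue exclusion, with a stated time of 96 h (a lower number here means a stronger inhibitor of growth, a higher number a weaker inhibitor of growth), compound 1 `Cc1ccc(S/C(=C/c2ccc(F)c(C)c2)C(=O)c2ccc(Br)cc2)cc1` gives 25000 nM.
In this assay compound 2 `CSc1ccc(/C=C(/SCc2ccc(C)cc2)C(=O)c2ccc(Cl)cc2)cc1` gives 25000 nM.

Compound 1 stands level with compound 2 at the digits shown; the gap between the two lies within the usual scatter of repeated measurements, so neither can be called the stronger or weaker inhibitor of growth. Going by the values given here, no step between measured compounds that differ in a single place is available here, so the two values give no direction for a structural change.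

Compound 3 `Cc1ccc(S/C(=C/c2ccc(C)s2)C(=O)c2ccc(Br)cc2)cc1` has not yet been measured. It differs from compound 1 in one place: 5-methylthiophen-2-yl in place of 4-fluoro-3-methylphenyl on a double-bonded chain carbon bound to a double-bonded chain carbon. The shared core otherwise stays the same. Among the compounds with values here, with no measured step to build on, and both measured compounds sitting at one value, the expected step in this assay from compound 1 to compound 3 is none beyond the scatter, that is no change at the digits printed from compound 1 to compound 3 (within the scatter). The estimate for compound 3 in this assay is 25000 nM, with a range from 10000 nM to 60000 nM.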

Compound 3, concentration for 50% growth inhibition: > 100000 nM
Compound 3 was reported as a limit (the forecaster's own chance of this, stated with the estimate: 35%); middle value at least 4.0-fold (0.60 log units) away from the limit.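

In this assay, the place on a double-bonded chain carbon bound to a double-bonded chain carbon proves sensitive to which ring it carries: 5-methylthiophen-2-yl in place of 4-fluoro-3-methylphenyl gives an at least 4.0-fold higher number from compound 1 to compound 3 (0.60 log units; beyond the scatter), so compound 3 is the weaker inhibitor of growth. Going by these compounds alone, compound 1 and compound 2 printed the same value and differ in more than one place, so this is the first single change with a readable direction. The step gives only a minimum size because compound 3 stands at a limit of the assay: the limit of > 100000 nM in this assay, at which 1 of the 3 values shown sits.

This one swap alters the ring size, the ring atoms and the fluorine together, so it cannot show which of these matters. Also open, on these data alone, is whether a pyridine ring, or a phenyl ring carrying an amine or a carboxylic acid, would hold or lose growth inhibition at this place.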